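Compound 1 to compound 4: replacing propyl with 3-methoxyphenyl

The compounds below may be only part of what the source reports. "The series", "measured", "known", "first", "only" and "open" are said of these compounds alone.

Measured in a functional assay on HeLa cells (Homo sapiens) for antiproliferative activity, read by MTT assay, with a stated time of 72 h; a lower number here means a stronger inhibitor, a higher number a weaker inhibitor:
- compound 1 `CCCn1ccnc1-c1cc(OC)c(OC)c(OC)c1`: > 100000 nM, a limit of the assay
- compound 2 `COc1cc(-c2nccn2-c2ccc3sccc3c2)cc(OC)c1OC`: 1400 nM
- compound 3 `COc1cc(-c2nccn2-c2ccc3[nH]ccc3c2)cc(OC)c1OC`: 4400 nM

Compound 1 gives no number, only a limit: it stands at the limit of > 100000 nM in this assay, at which 1 of the 3 values shown sits. In compound 4 `COc1cccc(-n2ccnc2-c2cc(OC)c(OC)c(OC)c2)c1`, 3-methoxyphenyl takes the place of propyl on an aromatic nitrogen (3-methoxyphenyl in place of propyl on an aromatic nitrogen). Among the measured compounds shown here, no measured pair isolates this change. Compound 2 at 1400 nM and compound 3 at 4400 nM also carry an aromatic group on that nitrogen, and both give numbers. A large expected step towards stronger inhibition in this assay follows, estimated as an at least 20-fold lower number from compound 1 to compound 4 (1.30 log units; beyond the scatter). Compound 4 is estimated at 5000 nM, with an expected range of 800 nM to 40000 nM.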

Compound 4, half-maximal inhibitory concentration: 11000 nM
Compound 4: the middle estimate sits 2.2-fold (0.34 log units) below what was measured; low and high end bracket the measured number.
By their numbers in this assay, from the lowest: compound 2; then compound 3; then compound 4. At a limit, above all of these: compound 1.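

In this assay, among the compounds shown here, 3-methoxyphenyl in place of propyl on the aromatic nitrogen gives an at least 9.0-fold lower number from compound 1 to compound 4 (0.95 log units; beyond the scatter), the only step at this position that can be read. That step is a lower bound, since compound 1 stands at a limit: the limit of > 100000 nM in this assay, at which 1 of the 4 values shown sits.

A single six-membered aromatic ring of carbon only, carrying a methoxy group, is thus enough here to give a measured number. The compounds shown leave open whether the methoxy group itself contributes, which a plain phenyl would test. They also leave open what a longer chain, or an amine on that ring, would do.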